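Removing a methyl from the aniline of compound 2

This account rests on a few compounds, and the source may have more. Where it says the series, first, only, none or still open, it means among the compounds named here.

Of the compounds shown here, two have been measured in a functional assay on CHO K cells for inhibition of growth hormone secretagogue receptor type 1 (Homo sapiens), read by FLIPR; a lower number here means a stronger inhibitor, a higher number a weaker inhibitor. Compound 1 `CCN(CC)c1ccc(NC(=O)c2c(-c3ccccc3-c3ccccc3)noc2C)cc1` carries a biphenyl on its core; in this assay compound 1 gives 6300 nM. Compound 2 `CCN(CC)c1ccc(NC(=O)c2c(-c3c(Cl)cccc3Cl)noc2CCC2OCCCO2)c(C)c1` carries instead a dichlorophenyl, a dioxane-bearing chain on the core and a methyl on the aniline; in this assay compound 2 gives 10 nM. Compound 2 thus stands at the lowest of the two numbers, and its gap to compound 1 lies far beyond the scatter. Compound 3 `CCN(CC)c1ccc(NC(=O)c2c(-c3c(Cl)cccc3Cl)noc2CCC2OCCCO2)cc1` is reached from compound 2 by a single change: hydrogen in place of methyl on an aromatic carbon. For the measured compounds named here, no measured pair in this set tracks that change, so the size of the step cannot be read from the neighbours. Since compound 2 already sits at 10 nM, the account expects compound 3 to keep most of that activity, with a step of a 3.0-fold higher number from compound 2 to compound 3 (0.48 log units; beyond the scatter) that is estimated, not measured. Compound 3 is expected to give about 30 nM in this assay, within a range from 8 nM to 150 nM.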

Compound 3, half-maximal inhibitory concentration: 14 nM
The estimate for compound 3 lay 2.1-fold (0.33 log units) above the measured number; the range from low to high includes it.
By their numbers in this assay, from the lowest: compounds 2 and 3 (each within the scatter of the next); then compound 1.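

Putting hydrogen in place of methyl on the aromatic carbon ortho to a large group and meta to a diethylamino group gives a 1.4-fold higher number from compound 2 to compound 3 (0.15 log units; within the scatter) in this assay. For the compounds shown here, this is the first pair in the set that differs in one place, and it shows that the methyl of the 4-(diethylamino)-2-methylphenyl is not required for a number in this range: the 4-(diethylamino)phenyl stands level with it within the scatter. No independent measurement is available that could account for this result.

As far as these compounds go, this single pair covers only methyl and hydrogen, so it remains open how a chlorine, a methoxy group or a longer chain such as ethyl on the same aromatic carbon would read. From the compounds shown here alone, it is also open whether the same swap would be as small with other groups elsewhere on the molecule, for instance with the biphenyl of compound 1, which differs from compound 3 in more than one place and so cannot be compared with it here.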